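Trimming a Methyl from a Benzyl Group

The source may hold more compounds than are shown below. What is called first, only, known or untested is meant among the compounds shown, and "the series" means these compounds.

Measured compounds:
compound 1 `C=C(Br)C(=O)Nc1cccc(/C=C2\SC(=O)N(Cc3ccc(Cl)cc3)C2=O)c1` gives 940 nM
compound 2 `C=C(Br)C(=O)Nc1ccc(/C=C2\SC(=O)N(Cc3cccc(Cl)c3)C2=O)cc1` gives 3400 nM
compound 3 `C=C(Br)C(=O)Nc1ccc(/C=C2\SC(=O)N(Cc3ccc(C)cc3)C2=O)cc1` gives 3400 nM

All three compounds were tested in a functional assay on L1210 cells (Mus musculus) for cytotoxicity, read by cell counting, with a stated time of 2 days; on this read-out lower numbers stand for stronger inhibition and higher numbers for weaker inhibition. Compound 3 sits level with compound 2 at the digits shown, and together these two carry the highest numbers of the three; compound 1 shows a lower number, and that gap lies beyond the scatter, but compound 1 differs from compound 3 in more than one place, so the two values can only be set side by side. Within the data shown here, the single step that can be read, no change at the digits printed from compound 2 to compound 3 (within the scatter), shows that swapping one substituted benzyl group for another left the number unchanged within the scatter.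

Compound 4 `C=C(Br)C(=O)Nc1ccc(/C=C2\SC(=O)N(Cc3ccccc3)C2=O)cc1` has not been tested. Its difference from compound 3 is hydrogen in place of methyl on an aromatic carbon. Among the measured compounds shown here, no measured pair shows exactly this removal of a methyl, so the only guide is that the benzyl substituent appeared not to matter in the step from compound 2 to compound 3. On that basis compound 4 is expected to sit close to compound 3, with the step of no change at the digits printed from compound 3 to compound 4 (within the scatter) estimated to stay within the scatter. Compound 4 is therefore estimated at 3400 nM, with a likely range from 1500 nM to 7500 nM.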

Compound 4, half-maximal inhibitory concentration: 1100 nM
Compound 4: middle estimate off by 3.1-fold (0.49 log units), on the high side; the measured number lies below the stated range.
By their numbers in this assay, from the lowest: compounds 1 and 4 (each within the scatter of the next); then compounds 2 and 3 (each within the scatter of the next).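

Taking the methyl off the benzyl ring does matter at this position: this assay shows a 3.1-fold lower number from compound 3 to compound 4 (0.49 log units; beyond the scatter), and hydrogen in place of chloro gives a 3.1-fold lower number from compound 2 to compound 4 (0.49 log units; beyond the scatter). The earlier flat step between the two substituted benzyl groups therefore did not mean that this ring is indifferent to substitution, since the 3-chlorophenyl and 4-methylphenyl groups sit level with each other while the plain phenyl group gives the lower number. No measurement at hand explains this difference.

The compounds shown compare hydrogen with just one methyl and one chloro, each at a single place on the ring, so it remains open whether a methoxy group, a fluorine or a hydroxyl group would also give a higher number than hydrogen, or whether a methyl elsewhere on the ring would act like the one in compound 3. Among these compounds, compound 1 differs from the others in more than one place, so no step to it can be read, and what its pattern of substitution contributes also remains open.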